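The source may report more compounds than this note shows. Statements on the series, on what has been measured and on what is new or still open speak of the compounds shown alone.

Compound 3 `CCc1cc(C(C)=O)c(O)cc1OCCCCCC(C)(C)C(=O)O` stands highest of the three measured compounds in an assay on isolated protein for binding affinity to leukotriene B4 receptor 1 (Homo sapiens), tested at 1 uM (on this read-out higher numbers stand for more inhibition at the one concentration tested (going by the name of the read-out) and lower numbers for less inhibition), where compound 3 gives 73%. Compound 2 `CCc1cc(C(C)=O)c(O)cc1OCCCCCC(C)(C)C#N` gives 53% in this assay, and compound 1 `CCc1cc(C(C)=O)c(O)cc1OCCCCC(C)(C)C#N` gives 30%. Every measured step points the same way: a number 23 percentage points higher from compound 1 to compound 2 (beyond the scatter), a number 20 percentage points higher from compound 2 to compound 3 (beyond the scatter) and a number 43 percentage points higher from compound 1 to compound 3 (beyond the scatter), so the number rises both as the chain grows and as carboxy takes the place of cyano.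

Compound 4 `CCc1cc(C(C)=O)c(O)cc1OCCCCCCSC` has not yet been tested in this assay. It differs from compound 3 in one place: (methylsulfanyl)methyl in place of 1-carboxy-1-methylethyl on a saturated chain carbon, five bonds along the chain from an oxygen on an aromatic ring. The carboxy that marked compound 3 leaves, and nothing like it or like the cyano of compound 2 enters.

The step that bears most directly on this is a number 20 percentage points higher from compound 2 to compound 3 (beyond the scatter), a modest gain when carboxy replaced cyano. Since compound 4 drops the carboxy and takes no cyano in its place, a fall in this assay is expected, and since the hydrogen-bond donor of compound 3 also goes, the fall may well exceed that step. Compound 4 is therefore estimated at 35%, within 10% to 60%, meaning an expected step of a number 38 percentage points lower from compound 3 to compound 4 (beyond the scatter).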

Compound 4, a percentage reported as inhibition, at one concentration (the size of the read-out at that concentration, not a potency): 14%
Compound 4: middle estimate off by 21 percentage points, on the high side; low and high end bracket the measured number.
By their numbers in this assay, from the lowest: compound 4; then compound 1; then compound 2; then compound 3.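

In this assay, the new chain end brings a number 59 percentage points lower from compound 3 to compound 4 (beyond the scatter) and a number 39 percentage points lower from compound 2 to compound 4 (beyond the scatter), so compound 4 stands lowest of the four compounds once neither carboxy nor cyano is present at this position. It even falls short of the nitrile with the shorter chain, with a number 16 percentage points lower from compound 1 to compound 4 (beyond the scatter), which shows that the earlier rise along the series does not come from chain growth alone: what sits at the chain end matters at least as much. No measurement shown here accounts for this fall.

The change to (methylsulfanyl)methyl removes the carboxy and its branching carbon with the two methyl groups in a single step, and it also shortens the group from 6 heavy atoms to 3, so the compounds shown cannot say which of these losses matters. An unbranched carboxylic acid on the same chain, a methyl ester in place of the acid, or a plain 1-methylethyl end would each separate these parts, and a primary amine at the chain end would test a different kind of group there.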